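The compounds below may be only part of what the source reports. "The series", "measured", "known", "first", "only" and "open" are said of these compounds alone.

Measured so far, in a functional assay on LoVo cells (Homo sapiens) for inhibition, read by MTT assay, with a stated time of 24 h; a higher number here means a weaker inhibitor, a lower number a stronger inhibitor:
Compound 1 `CC1(C)[C@H]2CC[C@]1(C)N(Cc1cn(-c3cccc(C#N)c3)nn1)C(=O)C2` gives 320 nM.
Compound 2 `CC1(C)[C@H]2CC[C@]1(C)N(Cc1cn(-c3ccc(F)cc3)nn1)C(=O)C2` gives 40 nM.
Compound 3 `Cc1ccc(-n2cc(CN3C(=O)C[C@@H]4CC[C@@]3(C)C4(C)C)nn2)cc1` gives 50 nM.

Compound 1 stands highest of the three numbers, so it is the weakest inhibitor here. Compound 4 `Cc1ccccc1-n1cc(CN2C(=O)C[C@@H]3CC[C@@]2(C)C3(C)C)nn1` differs from compound 1 only at the group on the aromatic nitrogen: 2-methylphenyl in place of 3-cyanophenyl on an aromatic nitrogen. Among the compounds with values here, two measured steps bear on this, both swapping out the same 3-cyanophenyl: an 8.0-fold lower number from compound 1 to compound 2 (0.90 log units; beyond the scatter) and a 6.4-fold lower number from compound 1 to compound 3 (0.81 log units; beyond the scatter). Both lower the number by a modest amount. Since 2-methylphenyl is another plain phenyl without the nitrile, a lower number in this assay is expected for compound 4 as well, though the methyl sits at a position not yet tested, so the estimate is less certain. Compound 4 is expected at 80 nM, in the range 30 nM to 250 nM, a step of a 4.0-fold lower number from compound 1 to compound 4 (0.60 log units; beyond the scatter).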

Compound 4, half-maximal inhibitory concentration: 80 nM
Estimate against measurement, compound 4: no gap at the digits printed; low and high end bracket the measured number.
By their numbers in this assay, from the lowest: compounds 2, 3 and 4 (each within the scatter of the next); then compound 1.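

In this assay, the swap to 2-methylphenyl gives a 4.0-fold lower number from compound 1 to compound 4 (0.60 log units; beyond the scatter), so a third group without the nitrile also lowers the number. The place of the methyl shows no measurable effect here: moving from 4-methylphenyl to 2-methylphenyl gives a 1.6-fold higher number from compound 3 to compound 4 (0.20 log units; within the scatter). Exchanging 4-fluorophenyl for 2-methylphenyl likewise gives a 2.0-fold higher number from compound 2 to compound 4 (0.30 log units; within the scatter), so these three groups cannot be told apart in this assay, and nothing available explains why they differ from 3-cyanophenyl. Still open, going by these compounds, is whether an amine or a carboxylic acid in place of the methyl would keep the number this low.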